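Diisopropylamino in place of diethylamino on the free-hydroxyl analogue

The compounds below may be only part of what the source reports. "The series", "measured", "known", "first", "only" and "open" are said of these compounds alone.

Measured compounds:
compound 1 `CCCCCCCCCCCCCC[C@H](OCOC)[C@H](CN(CC)CC)NC(=O)OC(C)(C)C` gives 0.84% in a functional assay on MDA-MB-231 cells (Homo sapiens) for antiproliferative activity, read by sulforhodamine B assay, with a stated time of 48 h, tested at 10 uM; on this read-out higher numbers stand for more inhibition at the one concentration tested (going by the name of the read-out) and lower numbers for less inhibition
compound 2 `CCCCCCCCCCCCCC[C@H](OCOC)[C@H](CN(C(C)C)C(C)C)NC(=O)OC(C)(C)C` gives 31% in this assay
compound 3 `CCCCCCCCCCCCCC[C@H](O)[C@H](CN(CC)CC)NC(=O)OC(C)(C)C` gives -1.45% in this assay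

Compound 3 holds the lowest of the three numbers. Its nearest neighbour is compound 1, and the step between them, a number 2.3 percentage points lower from compound 1 to compound 3 (within the scatter), is within the scatter, so the two cannot be told apart on this read-out. The furthest is compound 2, which stands well beyond the scatter above compound 3.

Compound 4 `CCCCCCCCCCCCCC[C@H](O)[C@H](CN(C(C)C)C(C)C)NC(=O)OC(C)(C)C` is the next member to be measured. It differs from compound 3 in one place: diisopropylamino in place of diethylamino on a saturated chain carbon, two bonds along the chain from an amide-type nitrogen

For the measured compounds named here, one measured step bears directly on this exchange: a number 30.2 percentage points higher from compound 1 to compound 2 (beyond the scatter), where the same amine swap was made on the methoxymethyl ether pair. That step is large and upward. Going by the values given here, only one such pair exists, so the transfer to the free-hydroxyl pair rests on a single precedent; however, the step of a number 2.3 percentage points lower from compound 1 to compound 3 (within the scatter) suggests that the hydroxyl and methoxymethyl variants of the diethylamino compounds behave alike in this assay, which supports carrying the amine effect across.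

A step of similar size upward is therefore expected: a number 29.5 percentage points higher from compound 3 to compound 4 (beyond the scatter). Compound 4 is estimated at 28%, with a range from 10% to 45%.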

Compound 4, a percentage reported as inhibition, at one concentration (the size of the read-out at that concentration, not a potency): -1.17%
Compound 4: the middle estimate sits 29.2 percentage points above what was measured; the measured number lies below the stated range.
By their numbers in this assay, from the lowest: compounds 3, 4 and 1 (each within the scatter of the next); then compound 2.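

With the free hydroxyl, the amine exchange has no readable effect in this assay, with a number 0.3 percentage points higher from compound 3 to compound 4 (within the scatter), while the loss of methoxymethyl, which made no readable difference on the diethylamino pair, is large on the diisopropylamino pair, with a number 32.2 percentage points lower from compound 2 to compound 4 (beyond the scatter). The effect of diisopropylamino in place of diethylamino is therefore not a fixed increment at this position, and it appears here only when the oxygen on a saturated carbon carries methoxymethyl: the same change on two cores in this assay, a number 30.2 percentage points higher (beyond the scatter) from compound 1 to compound 2 and a number 0.3 percentage points higher (within the scatter) from compound 3 to compound 4, 29.9 percentage points apart, beyond the scatter of two such steps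
Read the other way, the methoxymethyl group shows an effect only when diisopropylamino is present, so the two changes do not add independently in this set of compounds: the same change on two cores in this assay, a number 2.3 percentage points lower (within the scatter) from compound 1 to compound 3 and a number 32.2 percentage points lower (beyond the scatter) from compound 2 to compound 4, 29.9 percentage points apart, beyond the scatter of two such steps

From the compounds shown here alone, it remains open whether this dependence is specific to methoxymethyl or also holds for a methyl ether or an acetate on that oxygen, and whether a pyrrolidine or piperidine in place of diisopropylamino would behave the same way. All the readings come from a single concentration on one cell line, so the potency of compound 2 remains undefined.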